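This account rests on a few compounds, and the source may have more. Where it says the series, first, only, none or still open, it means among the compounds named here.

Values in a functional assay on KYSE-410 cells (Homo sapiens) for antiproliferative activity, read by MTT assay, with a stated time of 72 h; on this read-out higher numbers stand for weaker inhibition and lower numbers for stronger inhibition:
Compound 1 `COc1ccc(NC(=O)c2cc(=O)[nH]c3cc(Br)ccc23)cc1`: > 20000 nM (a limit)
Compound 2 `O=C(Nc1ccc(OC(F)(F)F)cc1)c1cc(=O)[nH]c2cc(Br)ccc12`: > 20000 nM (a limit)

Compound 2 gives > 20000 nM, which is a limit of the assay and not a number. Compound 3 `O=C(Nc1ccc(C(F)(F)F)cc1)c1cc(=O)[nH]c2cc(Br)ccc12` has not yet been measured. It differs from compound 2 in one place, on an aromatic carbon of a six-membered aromatic ring of carbon only, para to a large group, where trifluoromethyl stands in place of trifluoromethoxy: trifluoromethyl in place of trifluoromethoxy on an aromatic carbon.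

Among the measured compounds shown here, only one measured step bears on this change: a step that the two limits leave unreadable from compound 1 to compound 2. It cannot be sized, since both of its ends are limits: the limit of > 20000 nM in this assay, at which 2 of the 2 values shown sit. Neither measured compound therefore gives a number to work from, and no direction can be argued for compound 3. Any step is expected to stay within the usual scatter, and the likeliest report is the same limit again. The expected change is a step that the limit leaves unreadable from compound 2 to compound 3. The estimate in this assay for compound 3 is 25000 nM, with an expected range from 10000 nM to 50000 nM.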

Compound 3, half-maximal inhibitory concentration: > 20000 nM
Compound 3 was reported as a limit (the forecaster's own chance of this, stated with the estimate: 80%); the middle value does not contradict the limit.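

Compound 3 gives > 20000 nM in this assay, which is a limit and not a number. The steps among compound 1, compound 2 and compound 3 therefore cannot be read, and they all end at the same limit: the limit of > 20000 nM in this assay, at which 3 of the 3 values shown sit.

The compounds shown leave open how strongly each one acts in this assay, and which group, if any, would give a readable value.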